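This account rests on a few compounds, and the source may have more. Where it says the series, first, only, none or still open, it means among the compounds named here.

In a functional assay on MCF7 cells (Homo sapiens) for cytotoxicity, read by MTT assay, with a stated time of 48 h (a lower number here means a stronger inhibitor, a higher number a weaker inhibitor), two compounds sharing one core have been measured. Compound 1 `COc1cc(/C=C/C(=O)/C=C/c2nc3cc(C)ccc3n2C)ccc1O`, which carries methyl on an aromatic carbon, gives 4500 nM. Compound 2 `COc1cc(/C=C/C(=O)/C=C/c2nc3cc(Cl)ccc3n2C)ccc1O`, which carries chloro there, gives 4400 nM, so it stands level with compound 1 within the scatter. Compound 3 `COc1cc(/C=C/C(=O)/C=C/c2nc3cc([N+](=O)[O-])ccc3n2C)ccc1O` keeps the same core and has nitro in place of chloro on an aromatic carbon. For the measured compounds named here, only one measured step bears on this change, a 1.0-fold lower number from compound 1 to compound 2 (0.01 log units; within the scatter), with chloro in place of methyl on an aromatic carbon, and it lies within the scatter. Going by the values given here, this single step is a weak guide, since it involves no nitro group and no nitro compound has yet been measured. On this evidence, no step beyond the scatter is expected in this assay, although the range must stay wide. The expected step is a 1.1-fold lower number from compound 2 to compound 3 (0.04 log units; within the scatter). For compound 3, the estimated value is 4000 nM, with an expected range from 1700 nM to 9500 nM.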

Compound 3, half-maximal inhibitory concentration: 3700 nM
Compound 3: middle estimate off by 1.1-fold (0.03 log units), on the high side; the range from low to high includes it.
By their numbers in this assay, from the lowest: compounds 3, 2 and 1 (each within the scatter of the next).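

In this assay, nitro on this aromatic carbon of the six-membered ring carries hydrogen-bond acceptors where chloro carries none, yet this exchange gives only a 1.2-fold lower number from compound 2 to compound 3 (0.08 log units; within the scatter) and so moves the reading by no more than the scatter. The comparison with methyl at the same place reads alike, with a 1.2-fold lower number from compound 1 to compound 3 (0.09 log units; within the scatter), so methyl, chloro and nitro now stand level with one another, and the flat reading seen earlier for one pair of groups holds across all three. No measurement shown here accounts for this flat reading at this position.

The compounds shown leave open whether a group of another kind at this place, such as an amine, a carboxylic acid or a longer chain, would also stay within the scatter or would produce the first clear step in this series. They also leave open whether the rest of the shared core is as undemanding, as all three compounds differ in this one place only.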